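A few compounds are considered here, and "the series" means these few. Any claim that something is new, unique, unknown or untested is made for them only; others in the source may bear on it.

Compound 3 `Cc1c(C(=O)Nc2ccc(-c3ccccc3)cc2)nc2ccccc2c1O`, tested in a functional assay on A-375 cells (Homo sapiens) for antiproliferative activity, read by MTT assay, with a stated time of 24 h, tested at 0.14 ug/mL (a lower number here means a weaker effect, a higher number a stronger effect of the compound at the concentration tested), gives 1.98%. Among the three measured compounds its number is closest to that of compound 1 `CCc1ccc2nc(C(=O)Nc3c(F)cc(-c4cccc(F)c4)cc3F)c(C)c(O)c2c1`, which gives 1.57% in this assay, and furthest from that of compound 2 `Cc1c(C(=O)Nc2c(F)cc(-c3cccc(F)c3)cc2F)nc2ccc(C(F)(F)F)cc2c1O`, which gives 9.37%; both gaps lie within the scatter. Compound 4 `Cc1c(C(=O)Nc2ccc(-c3ccccc3)cc2)nc2ccccc2c1C(=O)O` differs from compound 3 by carboxy in place of hydroxy on an aromatic carbon. For the measured compounds named here, the only measured step, a number 7.8 percentage points higher from compound 1 to compound 2 (within the scatter), alters a different group at a different place and itself lies within the scatter, so no measured step bears directly on the carboxy-for-hydroxy change. No step beyond the scatter is therefore expected in this assay. Compound 4 is estimated at 3%, within 0% to 14%, a step of a number 1 percentage points higher from compound 3 to compound 4 (within the scatter) that is expected to remain within the scatter.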

Compound 4, a percentage reported as inhibition, at one concentration (the size of the read-out at that concentration, not a potency): 1.56%
Beside the measured number, compound 4's estimate is 1.4 percentage points above it; the range from low to high includes it.
By their numbers in this assay, from the lowest: compounds 4, 1, 3 and 2 (each within the scatter of the next).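

In this assay, for the compounds shown here, carboxy in place of hydroxy at the position opposite the ring nitrogen gives a number 0.4 percentage points lower from compound 3 to compound 4 (within the scatter), the first measured step at this place. On this core, the exchange therefore does not separate the two groups at the concentration tested. No measurement shown here accounts for this result.

As far as these compounds go, whether an amine or a methoxy group at this position would also stay within the scatter remains open. So does whether the same exchange would give a similar step on the cores of compound 1 and compound 2.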